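Dimethoxyphenyl for dichlorophenyl on the piperazine: thiazole series

A few compounds are considered here, and "the series" means these few. Any claim that something is new, unique, unknown or untested is made for them only; others in the source may bear on it.

Two cores are in play. Compound 1 `Cc1nc(-c2ccccc2F)c(C(=O)N2CCN(c3cc(Cl)cc(Cl)c3)CC2)s1` and compound 2 `Cc1nc(-c2ccccc2F)c(C(=O)N2CCN(c3cc(Cl)cc(Cl)c3)CC2)o1` share the same amine-bearing ring and the same aryl substituent, but the difference between the two cores is not broken down here. In a functional assay on HL-60 cells (Homo sapiens) for inhibition, read by MTT assay, with a stated time of 72 h (on this read-out higher numbers stand for weaker inhibition and lower numbers for stronger inhibition), compound 1 gives 157 nM, the highest number among the three measured compounds. In this assay compound 2 gives 60.2 nM.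

Compound 3 `COc1cc(OC)cc(N2CCN(C(=O)c3oc(C)nc3-c3ccccc3F)CC2)c1` carries the change 3,5-dimethoxyphenyl in place of 3,5-dichlorophenyl on an amine nitrogen in a ring on the core of compound 2. In this assay compound 3 gives 10.3 nM, which is a 5.8-fold lower number from compound 2 to compound 3 (0.77 log units; beyond the scatter), a step beyond the usual scatter.

Compound 4 `COc1cc(OC)cc(N2CCN(C(=O)c3sc(C)nc3-c3ccccc3F)CC2)c1` is the matching change on the core of compound 1: 3,5-dimethoxyphenyl in place of 3,5-dichlorophenyl on an amine nitrogen in a ring. The place of the change is the same, word for word, as for compound 3, so this is the same change on the other core. Going by the values given here, with only one measured example of it, the expectation for compound 4 rests on that single step: the estimated step in this assay from compound 1 to compound 4 is a 5.8-fold lower number from compound 1 to compound 4 (0.76 log units; beyond the scatter), set beside the measured step from compound 2 to compound 3 because a 5.8-fold lower number from compound 2 to compound 3 (0.77 log units; beyond the scatter) is the only guide available. The range is kept wide since the cores differ and a single pair cannot show whether the step carries over unchanged. On that basis compound 4 is expected to give 27 nM in this assay, with a likely span from 10 nM to 75 nM.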

Compound 4, half-maximal inhibitory concentration: 96.8 nM
Compound 4: the middle estimate sits 3.6-fold (0.55 log units) below what was measured; measured number outside the range, above it.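

In this assay the change on the second core gives a 1.6-fold lower number from compound 1 to compound 4 (0.21 log units; within the scatter), so on that core the swap to 3,5-dimethoxyphenyl makes no clear difference. The step measured on one core therefore does not carry over in size to the other: the same change on two cores in this assay, a 5.8-fold lower number (0.77 log units; beyond the scatter) from compound 2 to compound 3 and a 1.6-fold lower number (0.21 log units; within the scatter) from compound 1 to compound 4, 3.6-fold (0.56 log units) apart, beyond the scatter of two such steps
Going by these compounds alone, with only one pair on each core, this shows that the size of the step depended on the core in these two cases, but not which feature of the cores accounts for the gap or how the change would behave on a further core.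

Going by these compounds, it remains open whether the same dependence on the core would appear with other groups on the amine nitrogen in the ring, such as a phenyl bearing an amine or a carboxylic acid in place of 3,5-dimethoxyphenyl. Also open, on these data alone, is whether a longer chain in place of the methyl group on the core would widen or narrow the gap between the two steps.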